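A few compounds are considered here, and "the series" means these few. Any claim that something is new, unique, unknown or untested is made for them only; others in the source may bear on it.

Working notes on the series. In a functional assay on NCI-H522 cells (Homo sapiens) for cytotoxicity, read by sulforhodamine B assay, with a stated time of 48 h, tested at 10 uM (a lower number here means a stronger effect, a higher number a weaker effect of the compound at the concentration tested), compound 1 `COc1ccc(-c2cc(/C=C/C(=O)c3ccc(N)cc3)[nH]n2)cc1` gives -70%. Compound 2 `COc1ccc(-c2cc(/C=C/C(=O)c3ccc(N)cc3)[nH]n2)cc1OC` gives -84% in this assay. Compound 3 `COc1cc(C(=O)/C=C/c2cc(-c3cc(OC)c(OC)c(OC)c3)n[nH]2)cc(OC)c1OC` gives -97% in this assay, the lowest of the three numbers. The difference between the core of compound 3 and the core of compound 2 is not broken down here. One change occurs twice in the set: from compound 2 to compound 1 hydrogen in place of methoxy on an aromatic carbon the step is a number 14 percentage points higher from compound 2 to compound 1 (beyond the scatter). Compound 4 `COc1ccc(-c2cc(/C=C/C(=O)c3cc(OC)c(OC)c(OC)c3)[nH]n2)cc1OC` is not yet measured; it differs from compound 3 by hydrogen in place of methoxy on an aromatic carbon, the same kind of change, though here the place is also meta to a methoxy group. The step in this assay is expected to be about a number 14 percentage points higher from compound 3 to compound 4 (beyond the scatter), resting on the step of a number 14 percentage points higher from compound 2 to compound 1 (beyond the scatter). Compound 4 is therefore expected to give about -83%, between -96% and -65%.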

Compound 4, a percentage reported as activity, at one concentration (the size of the read-out at that concentration, not a potency): -94%
Compound 4: the middle estimate sits 11 percentage points above what was measured, within the range that was stated.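

In this assay, replacing methoxy with hydrogen on the core of compound 3 gives a step that is a number 3 percentage points higher from compound 3 to compound 4 (within the scatter). Set beside the step on the other core, it does not differ beyond what two such steps would scatter: the same change on two cores in this assay, a number 14 percentage points higher (beyond the scatter) from compound 2 to compound 1 and a number 3 percentage points higher (within the scatter) from compound 3 to compound 4, 11 percentage points apart, within the scatter of two such steps This shows no measurable dependence of the change on the core across these two pairs, but it does not establish a common step size, as only one of the two steps lies beyond the scatter and two pairs make no general rule.

The compounds shown leave open whether the step holds at other places on the aromatic rings. They also leave open how a hydroxyl group, a chlorine or an ethoxy group would read in place of the methoxy.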